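Trifluoromethyl Added to Compound 2: Clearance Expectation

The source may hold more compounds than are shown below. What is called first, only, known or untested is meant among the compounds shown, and "the series" means these compounds.

Three measured compounds share one core and differ only in the chain on the aromatic nitrogen. Compound 1 `Brc1cccc2c1nnn2CC1CCCC1` carries a cyclopentyl group; in an ADME assay on microsomes from liver (Mus musculus, strain NMRI) for metabolic stability, tested at 2.5 uM (on this read-out higher numbers stand for fast clearance and lower numbers for slow clearance), compound 1 gives 11.4 mL/min/g. Compound 2 `Brc1cccc2c1nnn2CC1CC1` carries a cyclopropyl group, and in this assay compound 2 gives 7.7 mL/min/g. Compound 3 `CCCCn1nnc2c(Br)cccc21` carries a propyl group, and in this assay compound 3 gives 8.3 mL/min/g. Compound 2 gives the lowest of the three numbers, though all three lie within the scatter of one another: a 1.5-fold lower number from compound 1 to compound 2 (0.17 log units; within the scatter), a 1.4-fold lower number from compound 1 to compound 3 (0.14 log units; within the scatter) and a 1.1-fold higher number from compound 2 to compound 3 (0.03 log units; within the scatter).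

Compound 4 `FC(F)(F)c1cc(Br)c2nnn(CC3CC3)c2c1` keeps the cyclopropyl chain of compound 2 and differs by trifluoromethyl in place of hydrogen on an aromatic carbon. For the measured compounds named here, none of the measured steps replaces an aromatic hydrogen; no step bears directly on this change, and every step that was measured stayed within the scatter. With nothing further to lean on, the expected step is no change at the digits printed from compound 2 to compound 4 (within the scatter), that is, no change beyond the scatter. Compound 4 is estimated at 7.7 mL/min/g in this assay, with a range from 3.5 mL/min/g to 17 mL/min/g.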

Compound 4, intrinsic clearance in a liver preparation (reported as CLH), per the amount of preparation that the assay uses: 7.7 mL/min/g
Compound 4: middle estimate and measured number agree at the digits printed; low and high end bracket the measured number.
By their numbers in this assay, from the lowest: compounds 2, 4, 3 and 1 (each within the scatter of the next).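

The earlier compounds shown here varied only the chain on the aromatic nitrogen, so compound 4 gives the first reading from the six-membered aromatic ring itself: in this assay, trifluoromethyl in place of hydrogen on this aromatic carbon, meta to a bromo group, gives no change at the digits printed from compound 2 to compound 4 (within the scatter) on the cyclopropyl compound. At this position, then, a group of 4 heavy atoms can replace a hydrogen atom without moving the clearance number beyond the scatter, at least with this chain and in this one read-out. No measurement shown offers an explanation for this result.

On these data alone, whether an amine, a carboxylic acid or a nitrile at the same carbon would also leave the number within the scatter remains open. So does whether trifluoromethyl here would give the same result with the cyclopentyl chain of compound 1.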